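The source may report more compounds than this note shows. Statements on the series, on what has been measured and on what is new or still open speak of the compounds shown alone.

In a functional assay on A2780 cells (Homo sapiens) for cytotoxicity, read by MTT assay, with a stated time of 48 h (a higher number here means a weaker inhibitor, a lower number a stronger inhibitor), compound 1 `CCn1cc(-c2nc3ccccc3[nH]2)c(=O)c2cc(F)c(N3CCNCC3)nc21` gives 4800 nM, the lowest of the three numbers available. Compound 3 `CCn1cc(-c2nc3ccccc3s2)c(=O)c2cc(F)c(N3CCNC(C)C3)c(F)c21` reads 9800 nM and compound 2 `CCn1cc(-c2nc3ccccc3[nH]2)c(=O)c2cc(F)c(N3CCNC(C)C3)c(F)c21` reads 11600 nM, and each of these lies above the number for compound 1 by more than the usual scatter. Compound 4 `CCn1cc(-c2nc3ccc(Cl)cc3[nH]2)c(=O)c2cc(F)c(N3CCNCC3)nc21` has not yet been measured. It keeps the core of compound 1 and differs in one place: chloro in place of hydrogen on an aromatic carbon. This is chloro in place of hydrogen on an aromatic carbon, which turns 1H-benzimidazol-2-yl into 6-chloro-1H-benzimidazol-2-yl.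

Within the data shown here, no measured pair carries this exact change. Among the measured compounds shown here, the closest evidence is the one step that alters the same substituent, 1,3-benzothiazol-2-yl in place of 1H-benzimidazol-2-yl, which gives a 1.2-fold lower number from compound 2 to compound 3 (0.07 log units; within the scatter). That step lies within the scatter, but it was taken on a core other than that of compound 1, so it bears on the question only loosely. On this single step, no shift beyond the scatter is expected in this assay, and the data offer no firm direction. The estimated value for compound 4 is 4500 nM, with an expected range from 1800 nM to 11000 nM. The expected change is small, a 1.1-fold lower number from compound 1 to compound 4 (0.03 log units; within the scatter).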

Compound 4, half-maximal inhibitory concentration: 6300 nM
For compound 4 the middle estimate is 1.4-fold (0.15 log units) below the measured one, within the range that was stated.
By their numbers in this assay, from the lowest: compounds 1, 4, 3 and 2 (each within the scatter of the next, the first and the last beyond it).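

In this assay, adding chloro to the six-membered aromatic ring of carbon only, which turns 1H-benzimidazol-2-yl into 6-chloro-1H-benzimidazol-2-yl, gives a 1.3-fold higher number from compound 1 to compound 4 (0.12 log units; within the scatter). Among these compounds, this is the first direct reading of a change on this ring on the core of compound 1, as the earlier step replaced the whole 1H-benzimidazol-2-yl group with 1,3-benzothiazol-2-yl on a different core; here a single chlorine atom in place of hydrogen leaves the two compounds indistinguishable in this assay. No measurement at hand accounts for this result or says what the chloro group does at this position.

A single substituent at one place on the ring cannot show whether the position stays this flat for other groups, such as methoxy, an amine or a carboxylic acid, any of which might move the number beyond the scatter. Going by these compounds, it also remains open whether chloro at this place would read the same way on the core of compound 2, where the piperazine-type ring carries a methyl group.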